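Swapping Isopropylamino for Benzyl(methyl)amino on a Shared Core

The source may hold more compounds than are shown below. What is called first, only, known or untested is meant among the compounds shown, and "the series" means these compounds.

Compound 1 `COc1ccc(Nc2cc(C)nc(SCc3nc4ccccc4[nH]3)n2)cc1` and compound 2 `Cc1cc(NC(C)C)nc(SCc2nc3ccccc3[nH]2)n1` share one core and differ in a single group on a nitrogen on an aromatic ring. In a functional assay on MCF7 cells (Homo sapiens) for cytotoxicity, read by MTT assay, with a stated time of 72 h (a higher number here means a weaker inhibitor, a lower number a stronger inhibitor), compound 1 gives 61100 nM. For compound 2 this assay reports only a limit, > 100000 nM, which is a bound of the assay and not a number. Compound 2 thus stands at the limit of > 100000 nM in this assay, at which 1 of the 2 values shown sits. The move between them is an at least 1.6-fold higher number from compound 1 to compound 2 (0.21 log units; that floor lies within the scatter), a step whose floor lies within the usual scatter, so it shows at most a weak drift toward a weaker inhibitor.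

Compound 3 `Cc1cc(N(C)Cc2ccccc2)nc(SCc2nc3ccccc3[nH]2)n1` has not yet been measured in this assay. Relative to compound 2 the change is benzyl(methyl)amino in place of isopropylamino on an aromatic carbon. For the measured compounds named here, the only measured step that touches the same nitrogen is the one from compound 1 to compound 2, and it offers no firm direction; with compound 2 itself known only as a limit, no size can be read from it. The step from compound 2 to compound 3 is therefore expected to be a number no higher from compound 2 to compound 3 (the limit leaves the size open). For compound 3 the estimate is 100000 nM, within a range of 40000 nM to 300000 nM.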

Compound 3, half-maximal inhibitory concentration: > 100000 nM
Compound 3 was reported as a limit (the forecaster's own chance of this, stated with the estimate: 50%); the middle value sits exactly at the limit.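

In this assay compound 3, like compound 2, is reported only as a limit and not as a number, so the step between these two cannot be read. The comparison with the (4-methoxyphenyl)amino group shows an at least 1.6-fold higher number from compound 1 to compound 3 (0.21 log units; that floor lies within the scatter), which gives no firm direction and at most a weak drift toward a weaker inhibitor. For the compounds shown here, compound 3 does add one thing: a group with a six-membered aromatic ring and no hydrogen-bond donor ends at the same reported limit as the ring-free isopropylamino group, leaving compound 1 as the only compound here with a number rather than a limit: the limit of > 100000 nM in this assay, at which 2 of the 3 values shown sit.

As far as these compounds go, how far this aromatic carbon can carry a change that gives a clear number remains open, and a cyclic amine such as morpholine or piperazine, or a phenylamino group with chlorine in place of the methoxy group, would test that. The compounds shown also leave open whether the hydrogen on this nitrogen matters, since no pair here changes that hydrogen alone.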